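The source may hold more compounds than are shown below. What is called first, only, known or untested is meant among the compounds shown, and "the series" means these compounds.

The study concerns a small set of compounds built on a shared core that carries two sulfonyl groups on one benzene ring, and the question is whether any of them slows the growth of pancreatic cancer cells. Activity was measured in a functional assay on MIA PaCa-2 cells (Homo sapiens) for inhibition, read by MTT assay, with a stated time of 3 days; on this read-out lower numbers stand for stronger inhibition and higher numbers for weaker inhibition.

Compound 1, `CCN(CC)S(=O)(=O)c1ccc(S(=O)(=O)N2CCC[C@@H](C(=O)N[C@@H]3CCN(C(=O)OC(C)(C)C)C3)C2)cc1`, gives > 10000 nM in this assay, which is a limit of the measurement rather than a number. Compound 2, `CCOC(=O)[C@@H]1CCC[C@@H](S(=O)(=O)c2ccc(S(=O)(=O)N(CC)CC)cc2)C1`, likewise gives only the limit > 10000 nM. Compound 3, `CCN(CC)S(=O)(=O)c1ccc(S(=O)(=O)N2CCC[C@@H](C(=O)N(C)C(C)C)C2)cc1`, also reaches only the limit > 10000 nM. So compound 3 stands where every other measured compound stands, at the limit of > 10000 nM in this assay, at which 3 of the 3 values shown sit; no compound in the set has yet shown a measurable number.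

Compound 4, `CCN(CC)S(=O)(=O)c1ccc(S(=O)(=O)N2CCC[C@@H](C(=O)NC3CN(C(=O)C4CC4)C3)C2)cc1`, differs from compound 3 in one place: (1-(cyclopropylcarbonyl)azetidin-3-yl)amino in place of isopropyl(methyl)amino on a carbonyl carbon. Among the compounds with values here, since all measured values sit at the same limit, there is no step between measured compounds from which to read a trend; in particular, compound 1, which carries a ring-bearing amide on the same carbonyl, gives > 10000 nM.

On this basis compound 4 is expected to show no step beyond the scatter, a step that the limit leaves unreadable from compound 3 to compound 4, and most likely to return another limit. The estimate for compound 4 in this assay is therefore 15000 nM, with a range from 4000 nM to 60000 nM.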

Compound 4, half-maximal inhibitory concentration: > 10000 nM
Compound 4: no number, only a limit; the forecaster's own chance of this, stated with the estimate: 75%; the middle value lies beyond the limit too.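

In this assay no step from compound 3 or compound 1 to compound 4 can be read, since all of these compounds give only a limit: the limit of > 10000 nM in this assay, at which 4 of the 4 values shown sit.

The compounds shown leave open how far past that limit each one lies, and whether any change to the shared core would give a measurable number in this assay at all.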